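A second hydroxy on the weakest aryl hydrazone

The compounds below may be only part of what the source reports. "The series", "measured", "known", "first", "only" and "open" are said of these compounds alone.

Three hydrazone ureas share one core and differ only in the aryl group attached to the carbon with a double bond to nitrogen. Compound 1 `CN(C)CCn1cnnc1-c1cc(Oc2ccc(NC(=O)N/N=C/c3c(Cl)cccc3Cl)cc2F)ccn1` gives 350 nM in a functional assay on NCI-H460 cells (Homo sapiens) for cytotoxicity, read by MTT assay, with a stated time of 72 h; a lower number here means a stronger inhibitor, a higher number a weaker inhibitor. Compound 2 `CN(C)CCn1cnnc1-c1cc(Oc2ccc(NC(=O)N/N=C/c3cccc(Cl)c3Cl)cc2F)ccn1` gives 72 nM in this assay. Compound 3 `CN(C)CCn1cnnc1-c1cc(Oc2ccc(NC(=O)N/N=C/c3ccc(O)cc3)cc2F)ccn1` gives 1780 nM in this assay, the highest number of the three, with compound 1 nearest to it and compound 2 furthest from it. Exchanging one aryl group for another moved the numbers clearly each time: a 4.9-fold lower number from compound 1 to compound 2 (0.69 log units; beyond the scatter), a 5.1-fold higher number from compound 1 to compound 3 (0.71 log units; beyond the scatter) and a 25-fold higher number from compound 2 to compound 3 (1.39 log units; beyond the scatter).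

Compound 4 `CN(C)CCn1cnnc1-c1cc(Oc2ccc(NC(=O)N/N=C/c3ccc(O)cc3O)cc2F)ccn1` keeps the aryl group of compound 3 and adds to it: hydroxy in place of hydrogen on an aromatic carbon. None of the three measured steps bears directly on this change; each exchanged the whole aryl group, and none added a substituent to a ring that already carried a hydroxy group. They show how wide the spread across aryl groups can be, but give no reading for a second hydroxy. Without a precedent, only a small step is expected, a 1.1-fold higher number from compound 3 to compound 4 (0.05 log units; within the scatter). Compound 4 is therefore expected to give about 2000 nM in this assay, with a range from 700 nM to 6000 nM.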

Compound 4, half-maximal inhibitory concentration: 11300 nM
Compound 4: middle estimate off by 5.7-fold (0.75 log units), on the low side, and the stated range ends below it.
By their numbers in this assay, from the lowest: compound 2; then compound 1; then compound 3; then compound 4.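

Adding a single hydroxy to a ring that already carries one, ortho to a large group and meta to a hydroxy group, gives a 6.3-fold higher number from compound 3 to compound 4 (0.80 log units; beyond the scatter) in this assay and so shows that this position does not tolerate the change silently. The step is about as large as the exchanges of whole aryl groups between the dichlorophenyl compounds and compound 3, although only one oxygen enters. Against the dichlorophenyl compounds, 2,4-dihydroxyphenyl widens the spread across aryl groups to a 32-fold higher number from compound 1 to compound 4 (1.51 log units; beyond the scatter) and a 160-fold higher number from compound 2 to compound 4 (2.20 log units; beyond the scatter), and compound 4 now has the highest number of the four. Nothing at hand explains why the added hydroxy moves the number in this direction.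

The compounds shown leave open whether the rise belongs to the hydroxy itself or would also follow from a methoxy or an amino group at the same place. They also leave open whether a second hydroxy elsewhere on the 4-hydroxyphenyl ring would give a step of the same size.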